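The source may report more compounds than this note shows. Statements on the series, on what has been measured and on what is new or still open speak of the compounds shown alone.

Compound 1 `O=C(CCCCC1CCSS1)NCc1cn(CCCOc2ccc3cc(C(=O)O)c(=O)oc3c2)nn1`: 73.5%
Compound 2 `O=C(CCCCC1CCSS1)NCc1cn(CCCCCOc2ccc3ccc(=O)oc3c2)nn1`: 84.9%

In a functional assay on PC-12 cells (Rattus norvegicus) for cytotoxicity, read by MTT assay, with stated times of 3 h and 2 h, tested at 50 uM (a lower number here means a weaker effect, a higher number a stronger effect of the compound at the concentration tested), compound 2 gives 84.9%, the higher of the two numbers; compound 1 gives 73.5%, and that gap lies beyond the scatter. Compound 3 `COc1ccc(-c2cc3ccc(OCCCCCn4cc(CNC(=O)CCCCC5CCSS5)nn4)cc3oc2=O)cc1` differs from compound 2 in one place: 4-methoxyphenyl in place of hydrogen on an aromatic carbon. Among the measured compounds shown here, no measured pair shows a change of this kind, so there is no step to lean on. Compound 2 already stands high, and for compound 3 a step of a number 4.9 percentage points lower from compound 2 to compound 3 (within the scatter) is expected, small and within the scatter. Compound 3 is estimated at 80%, within 64% to 93%.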

Compound 3, a percentage reported as activity, at one concentration (the size of the read-out at that concentration, not a potency): 52.8%
Compound 3: middle estimate off by 27.2 percentage points, on the high side; the whole stated range lies above it.
By their numbers in this assay, from the lowest: compound 3; then compound 1; then compound 2.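

In this assay, the aromatic carbon two atoms from the ring oxygen proves sensitive to substitution: putting 4-methoxyphenyl in place of hydrogen gives a number 32.1 percentage points lower from compound 2 to compound 3 (beyond the scatter). A single added group at this position is therefore enough to shift the read-out well past ordinary variation. No measurement shown bears on the reason for this fall. From the compounds shown here alone, it remains open whether the fall comes from the whole 4-methoxyphenyl group or from its ring alone. A plain phenyl or a methyl on the same carbon would help separate these possibilities.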